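Carboxyphenyl replacing methyl on the chain carbon of compound 1

A few compounds are considered here, and "the series" means these few. Any claim that something is new, unique, unknown or untested is made for them only; others in the source may bear on it.

Compound 1 `CCn1nc(-c2cccnc2)c2ccccc2c1=O` gives 87% in an assay on isolated protein (Oryctolagus cuniculus) with Thromboxane-A synthase (Homo sapiens) as the target, tested at 1 uM (a higher number here means more inhibition at the concentration tested (going by the name of the read-out), a lower number less inhibition), the lower of the two numbers measured; compound 2 `O=c1c2ccccc2c(-c2cccnc2)nn1Cc1cccc(Cl)c1` gives 95%, with a number 8 percentage points higher from compound 1 to compound 2 (within the scatter). Compound 3 `O=C(O)c1ccc(Cn2nc(-c3cccnc3)c3ccccc3c2=O)cc1` differs from compound 1 in that (4-carboxyphenyl in place of methyl on a saturated chain carbon bound to an aromatic nitrogen). Among the measured compounds shown here, the only step that bears on this change is the one from compound 1 to compound 2, in which an aryl group entered at the same place and moved the number only within the scatter. A similar outcome is therefore expected here, with a number 2 percentage points lower from compound 1 to compound 3 (within the scatter), no move beyond the scatter. Compound 3 is estimated at 85%, between 60% and 97%.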

Compound 3, a percentage reported as inhibition, at one concentration (the size of the read-out at that concentration, not a potency): 64%
Beside the measured number, compound 3's estimate is 21 percentage points above it; measured number inside the range.
By their numbers in this assay, from the lowest: compound 3; then compounds 1 and 2 (each within the scatter of the next).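

In this assay the place on the saturated chain carbon bound to an aromatic nitrogen proves sensitive to the group it carries: 4-carboxyphenyl gives a number 23 percentage points lower from compound 1 to compound 3 (beyond the scatter) and a number 31 percentage points lower from compound 2 to compound 3 (beyond the scatter) while the step to 3-chlorophenyl stayed within the scatter. An aryl group here therefore does not fix the number by itself, and what it carries counts. Nothing available accounts for this loss.

Open, going by these compounds, is whether an unsubstituted phenyl, a methyl ester or an amine in place of the carboxylic acid would keep the number near that of compound 1, and whether moving the carboxylic acid around the ring changes it.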